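One Methyl Added to Compound 2

A few compounds are considered here, and "the series" means these few. Any claim that something is new, unique, unknown or untested is made for them only; others in the source may bear on it.

In a physicochemical assay for solubility, in simulated intestinal fluid (on this read-out lower numbers stand for lower solubility and higher numbers for higher solubility), compound 1 (`Cc1cc(N2CCc3nnn(Cc4ccc5ncccc5c4)c3C2=O)sn1`) gives < 1 ug/mL as a limit of the assay. Among the compounds with values here, compound 2 (`Cc1cc(-n2ccc3nnn(Cc4ccc5ncccc5c4)c3c2=O)sn1`) gives 4.8 ug/mL as the only actual number so far. Compound 3 (`Cc1cc(-n2ccc3nnn([C@@H](C)c4ccc5ncccc5c4)c3c2=O)sn1`) differs by methyl in place of hydrogen on a saturated chain carbon bound to an aromatic carbon and an aromatic nitrogen and nothing else: methyl in place of hydrogen on a saturated chain carbon bound to an aromatic carbon and an aromatic nitrogen. Within the data shown here, no measured pair shows this change, so no step beyond the scatter is expected in this assay in either direction. The estimated step of a 1.3-fold higher number from compound 2 to compound 3 (0.10 log units; within the scatter) stays small. Compound 3 is expected at 6 ug/mL within an estimated range of 2 ug/mL to 18 ug/mL in this measurement.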

Compound 3, solubility: 22.4 ug/mL
Estimate against measurement, compound 3: 3.7-fold (0.57 log units) below; the measured number lies above the stated range.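

In this assay, this position gives its first measured step, a 4.7-fold higher number from compound 2 to compound 3 (0.67 log units; beyond the scatter): a single methyl in place of hydrogen on this saturated chain carbon is enough to move the read-out beyond the scatter. Compound 1 adds no step at this position, and its reading is a limit: the limit of < 1 ug/mL in this assay, at which 1 of the 3 values shown sits.

The compounds shown leave open whether the mirror-image arrangement of this methyl would give the same step. They also leave open whether an ethyl or a hydroxymethyl on this carbon would move the read-out further, or in the opposite direction.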